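The source may report more compounds than this note shows. Statements on the series, on what has been measured and on what is new or still open speak of the compounds shown alone.

Within the data shown here, compound 3 `CC(C)(C)C(=O)N1CCC(NCC[S+]([O-])C(c2ccc(F)cc2)c2ccc(F)cc2)CC1` gives 11200 nM in an assay on membranes from Cortex for displacement of a labelled ligand from Sigma non-opioid intracellular receptor 1 (Cavia porcellus), read by scintillation counting, with a stated time of 120 min (on this read-out higher numbers stand for weaker inhibition and lower numbers for stronger inhibition), the highest of the three numbers measured so far. Compound 1 `O=C(c1ccccc1)N1CCC(NCC[S+]([O-])C(c2ccc(F)cc2)c2ccc(F)cc2)CC1` gives 585 nM in this assay, and compound 2 `O=C(c1ccc(F)cc1)N1CCC(NCC[S+]([O-])C(c2ccc(F)cc2)c2ccc(F)cc2)CC1` gives 1440 nM. Compound 3 therefore sits at the top of the set: a 19-fold higher number from compound 1 to compound 3 (1.28 log units; beyond the scatter) and a 7.8-fold higher number from compound 2 to compound 3 (0.89 log units; beyond the scatter). Within the pair of aromatic amides the step is a 2.5-fold higher number from compound 1 to compound 2 (0.39 log units; beyond the scatter).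

Compound 4 `CC(C)(C)CN1CCC(NCC[S+]([O-])C(c2ccc(F)cc2)c2ccc(F)cc2)CC1` differs from compound 3 by neopentyl in place of (tert-butyl)carbonyl on an amine nitrogen in a ring. Among the measured compounds shown here, none of the measured steps covers this change: each of them keeps the carbonyl in place and varies only the group on the carbonyl carbon. What they do show is that this end of the shared core moves the numbers strongly, since a 19-fold higher number from compound 1 to compound 3 (1.28 log units; beyond the scatter) and a 7.8-fold higher number from compound 2 to compound 3 (0.89 log units; beyond the scatter) are both beyond the scatter, whereas a 2.5-fold higher number from compound 1 to compound 2 (0.39 log units; beyond the scatter) is a smaller shift. For the measured compounds named here, removing the carbonyl itself is a change of a different kind, and no measured pair fixes its direction. For compound 4 the expectation is nonetheless a step beyond the scatter in this assay, a 37-fold lower number from compound 3 to compound 4 (1.57 log units; beyond the scatter), taken as a move to a lower number, with wide uncertainty on both sides. Compound 4 is estimated at 300 nM, with a range from 30 nM to 4000 nM.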

Compound 4, inhibition constant: 542 nM
Beside the measured number, compound 4's estimate is 1.8-fold (0.26 log units) below it, and the stated range covers the measured number.
By their numbers in this assay, from the lowest: compounds 4 and 1 (each within the scatter of the next); then compound 2; then compound 3.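

In this assay, among these compounds, the high number of compound 3 belongs to the (tert-butyl)carbonyl group as a whole and not to the five-carbon tert-butyl end alone: neopentyl in place of it on the amine nitrogen in a ring gives a 21-fold lower number from compound 3 to compound 4 (1.32 log units; beyond the scatter) and is the first measured change that removes the carbonyl rather than varying the group on it. Against the aromatic amides, the same neopentyl gives a 2.7-fold lower number from compound 2 to compound 4 (0.42 log units; beyond the scatter) for the fluorinated case and a 1.1-fold lower number from compound 1 to compound 4 (0.03 log units; within the scatter) for the benzoyl case, so in this small set neither a carbonyl nor an aromatic ring on this nitrogen is needed to reach a number that cannot be told apart from that of the benzoyl compound. No measurement is available that accounts for any of these steps.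

A benzyl or 4-fluorobenzyl group on this nitrogen would show whether removing the carbonyl moves the aromatic amides as it moves the (tert-butyl)carbonyl compound. Shorter chains such as ethyl, or a free ring amine hydrogen, would show how much of the neopentyl group this position requires.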